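A few compounds are considered here, and "the series" means these few. Any claim that something is new, unique, unknown or untested is made for them only; others in the source may bear on it.

Working notes on the series.

Among the compounds with values here, compound 1 `CN1CCC(CNS(=O)(=O)c2ccccc2Nc2cc(-c3ccc4ccn(C)c4c3)c3nccnc3c2)C1` is the one compound of the three measured that gives a number: in an assay on lysate for inhibition of 6-phosphofructo-2-kinase/fructose-2,6-bisphosphatase 3 (Homo sapiens), with stated times of 0.5 min and 45 min (a lower number here means a stronger inhibitor, a higher number a weaker inhibitor), compound 1 gives 4640 nM. Compound 2 `CNS(=O)(=O)c1ccccc1Nc1cc(-c2ccc3ccn(C)c3c2)c2nccnc2c1` reaches only a limit of this assay, > 100000 nM. Compound 3 `CN(Cc1cncnc1)S(=O)(=O)c1ccccc1Nc1cc(-c2ccc3ccn(C)c3c2)c2nccnc2c1` likewise stands at a limit in this assay, > 100000 nM; it is one of the two values that sit at this limit (the limit of > 100000 nM in this assay, at which 2 of the 3 values shown sit), so nothing closer can be said of where it stands.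

Compound 4 `Cn1ccc2ccc(-c3cc(Nc4ccccc4S(=O)(=O)NCC4CCOCC4)cc4nccnc34)cc21` differs from compound 3 by ((oxan-4-yl)methyl)amino in place of methyl((pyrimidin-5-yl)methyl)amino on a sulfonyl sulfur. Within the data shown here, two measured steps bear on it. Among the measured compounds shown here, the step of an at least 21-fold higher number from compound 1 to compound 3 (1.33 log units; beyond the scatter) is the one that leads to compound 3, and the step of an at least 21-fold higher number from compound 1 to compound 2 (1.33 log units; beyond the scatter) is of the same kind. The step that the two limits leave unreadable from compound 2 to compound 3 gives no direction. Compound 4 carries a sulfonamide hydrogen and a saturated ring on the chain, as compound 1 does, and it is expected to fall between the two, the step of an at least 2.5-fold lower number from compound 3 to compound 4 (0.39 log units; beyond the scatter) being a move down from the limit. For compound 4 the estimate in this assay is 40000 nM, within 8000 nM to 200000 nM.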

Compound 4, half-maximal inhibitory concentration: > 100000 nM
Compound 4 was reported as a limit; the forecaster's own chance of this, stated with the estimate: 40%; middle value at least 2.5-fold (0.39 log units) away from the limit.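

Placing oxan-4-yl in place of 1-methylpyrrolidin-3-yl on a saturated chain carbon bound to a sulfonamide nitrogen gives an at least 21-fold higher number from compound 1 to compound 4 (1.33 log units; beyond the scatter) in this assay. Compound 1 and compound 4 both keep the sulfonamide hydrogen and a saturated ring on the chain, so these two features alone do not secure a measured number, and among the compounds shown only compound 1 gives one. The value of compound 4 is a limit, and the steps to it from compound 2 and compound 3 cannot be read, since both ends of each are limits: the limit of > 100000 nM in this assay, at which 3 of the 4 values shown sit.

From the compounds shown here alone, the order of compound 2, compound 3 and compound 4 among themselves stays open. Also open, going by these compounds, is whether 1-methylpiperidin-4-yl, pyrrolidin-3-yl without its methyl, or an open-chain dimethylamine on the same chain would retain the measurable inhibition of compound 1.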